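Acyl chain trimming in a metabotropic glutamate receptor 3 series

The source may hold more compounds than are shown below. What is called first, only, known or untested is meant among the compounds shown, and "the series" means these compounds.

Compound 1 `CCC(=O)c1ccc(OCCCCOc2cc(C(=O)O)ccc2OC)c(C)c1O` gives 62.5% in an assay on HEK293 cells for positive allosteric modulation of metabotropic glutamate receptor 3 (Rattus norvegicus), read by thallium flux, with a stated time of 2.5 min; on this read-out higher numbers stand for larger maximal responses and lower numbers for smaller maximal responses. Compound 2 `COc1ccc(C(=O)O)cc1OCCCCOc1ccc(C(C)=O)c(O)c1C` differs by hydrogen in place of methyl on a saturated chain carbon bound to a carbonyl carbon, and in this assay compound 2 gives 34.8%; the step is a number 27.7 percentage points lower from compound 1 to compound 2 (beyond the scatter). Compound 3 `Cc1cc(C(=O)O)ccc1OCCCCOc1ccc(C(=O)C(C)C)c(O)c1C` carries a different core, and the difference between the two cores is not broken down here; in this assay compound 3 gives 25.2%. Compound 4 `CCC(=O)c1ccc(OCCCCOc2ccc(C(=O)O)cc2C)c(C)c1O` differs from compound 3 by hydrogen in place of methyl on a saturated chain carbon bound to a carbonyl carbon and a saturated chain carbon, the same kind of change as that from compound 1 to compound 2, though here the place is also bound to a saturated chain carbon. The earlier step ran downward, yet compound 3 already stands low, so only a small to modest step is expected, a number 14.8 percentage points higher from compound 3 to compound 4 (beyond the scatter), because the value of compound 3 25.2% leaves limited room downward. The estimate for compound 4 is 40%, expected between 22% and 60%.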

Compound 4, largest response reached (reported as percent of maximum), in percent of the reference or control that the assay uses: 22.7%
Compound 4: middle estimate off by 17.3 percentage points, on the high side; the range from low to high includes it.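

In this assay, hydrogen in place of methyl on the acyl chain gives a number 2.5 percentage points lower from compound 3 to compound 4 (within the scatter), so on the core of compound 3 the change leaves no readable mark. The size of the step therefore does not carry over between these two cores: the same change on two cores in this assay, a number 27.7 percentage points lower (beyond the scatter) from compound 1 to compound 2 and a number 2.5 percentage points lower (within the scatter) from compound 3 to compound 4, 25.2 percentage points apart, beyond the scatter of two such steps

With a single pair on each core, this does not show whether the core or the starting chain, isopropylcarbonyl to propanoyl in the newer pair, accounts for the gap, and it gives no rule for any other core. The compounds shown leave open how a butanoyl chain would read on either core, and whether an amide in place of the carboxylic acid would alter the step.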